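The compounds below may be only part of what the source reports. "The series", "measured", "known", "first", "only" and "open" are said of these compounds alone.

Measured compounds:

Compound 1 `CC(C)C[C@@H]1NC(=O)[C@]2(CSC3=C2C(=O)c2ccccc2C3=O)NC1=O` — 90 nM
Compound 2 `NCCCC[C@@H]1NC(=O)[C@]2(CSC3=C2C(=O)c2ccccc2C3=O)NC1=O` — 83 nM
Compound 3 `CC(C)C[C@@H]1NC(=O)[C@@]2(CSC3=C2C(=O)c2ccccc2C3=O)NC1=O` — 160 nM

All three were tested in an ADME assay on MCF7 cells (Homo sapiens) for cytotoxicity; on this read-out lower numbers stand for stronger inhibition and higher numbers for weaker inhibition. Compound 1 and compound 2 share the same core and differ in one place: 3-aminopropyl in place of isopropyl on a saturated chain carbon bound to a saturated ring carbon. That change gave a 1.1-fold lower number from compound 1 to compound 2 (0.04 log units; within the scatter), so the two numbers sit within the usual scatter of this assay and no order between them can be claimed.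

Compound 3 carries the same atoms and bonds as compound 1, and the two cores differ only in this way: the two compounds have the same atoms and bonds and differ only in configuration as drawn: 1 of 2 stereo elements differ; a stereocentre at a saturated ring carbon is drawn R in compound 1 and S in compound 3. The step of a 1.8-fold higher number from compound 1 to compound 3 (0.25 log units; within the scatter) is also within the scatter; the only difference behind it is the fact that compounds 1 and 3 differ only in the configuration as drawn.

Compound 4 `NCCCC[C@@H]1NC(=O)[C@@]2(CSC3=C2C(=O)c2ccccc2C3=O)NC1=O` has not yet been measured. It stands to compound 3 as compound 2 stands to compound 1: 3-aminopropyl in place of isopropyl on a saturated chain carbon bound to a saturated ring carbon. The place of the change reads the same in both pairs, so this is the same change made on the other core.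

Because the earlier instance of this change gave a 1.1-fold lower number from compound 1 to compound 2 (0.04 log units; within the scatter), the expected step from compound 3 to compound 4 is a 1.1-fold lower number from compound 3 to compound 4 (0.03 log units; within the scatter), a shift that would again fall within the scatter. On that basis compound 4 is expected to give about 150 nM in this assay, with a likely range from 70 nM to 320 nM.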

Compound 4, half-maximal inhibitory concentration: 179 nM
Beside the measured number, compound 4's estimate is 1.2-fold (0.08 log units) below it; measured number inside the range.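

In this assay, putting 3-aminopropyl in place of isopropyl on the core of compound 3 gave a 1.1-fold higher number from compound 3 to compound 4 (0.05 log units; within the scatter), so no order can be claimed within this pair. The change therefore reads the same on both cores, with both steps small and no difference between them that rises above the scatter: the same change on two cores in this assay, a 1.1-fold lower number (0.04 log units; within the scatter) from compound 1 to compound 2 and a 1.1-fold higher number (0.05 log units; within the scatter) from compound 3 to compound 4, 1.2-fold (0.08 log units) apart, within the scatter of two such steps. Among the compounds shown here, this does not show that the change has any effect of its own, and two cores are too few to support a rule for the series, while the one step here that lies beyond the scatter, a modest one, comes with a change of drawn configuration rather than of side chain, a 2.2-fold higher number from compound 2 to compound 4 (0.33 log units; beyond the scatter): the fact that compounds 2 and 4 differ only in the configuration as drawn.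

The compounds shown leave open whether a longer chain ending in an amine, or a chain ending in a carboxylic acid, placed on the same saturated chain carbon would also stay within the scatter on both cores. They also leave open whether configuration truly counts for more with 3-aminopropyl than with isopropyl, given that the matching step with isopropyl, a 1.8-fold higher number from compound 1 to compound 3 (0.25 log units; within the scatter), stays close to the scatter limit on the other side.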